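Isopropyl for methyl on the aryl triazole series

The source may report more compounds than this note shows. Statements on the series, on what has been measured and on what is new or still open speak of the compounds shown alone.

Compound 2 `Cc1ccc(-n2cc(COc3cccc(NC(=O)Nc4ccc(Cl)c(C(F)(F)F)c4)c3)nn2)cc1` is one of a set of urea compounds sharing a common core, measured in a functional assay on HepG2 cells (Homo sapiens) for inhibition, read by MTT assay, with a stated time of 72 h; a higher number here means a weaker inhibitor, a lower number a stronger inhibitor. In this assay compound 2 gives 5430 nM, the highest number among the measured compounds. Compound 1 `N#Cc1ccccc1-n1cc(COc2cccc(NC(=O)Nc3ccc(Cl)c(C(F)(F)F)c3)c2)nn1` gives 1970 nM, and compound 3 `N#Cc1ccc(-n2cc(COc3cccc(NC(=O)Nc4ccc(Cl)c(C(F)(F)F)c4)c3)nn2)cc1` gives 2980 nM. The step of a 2.8-fold higher number from compound 1 to compound 2 (0.44 log units; beyond the scatter) lies beyond the scatter, whereas a 1.8-fold lower number from compound 2 to compound 3 (0.26 log units; within the scatter) and a 1.5-fold higher number from compound 1 to compound 3 (0.18 log units; within the scatter) stay within it.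

Compound 4 `CC(C)c1ccc(-n2cc(COc3cccc(NC(=O)Nc4ccc(Cl)c(C(F)(F)F)c4)c3)nn2)cc1` is not yet measured. It differs from compound 2 in one place: isopropyl in place of methyl on an aromatic carbon.

For the measured compounds named here, only one measured step touches the same position: a 1.8-fold lower number from compound 2 to compound 3 (0.26 log units; within the scatter), where a nitrile replaced the methyl and the number did not move beyond the scatter. The larger step of a 2.8-fold higher number from compound 1 to compound 2 (0.44 log units; beyond the scatter) swapped a whole different aryl group and so speaks less directly to this change. With a single, small relevant step, the expectation is that the change from methyl to isopropyl moves this assay little, if at all, and compound 4 is expected to land near compound 2, a step of a 1.2-fold lower number from compound 2 to compound 4 (0.08 log units; within the scatter).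

Compound 4 is estimated at 4500 nM, with a range from 1500 nM to 13000 nM.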

Compound 4, half-maximal inhibitory concentration: 2470 nM
For compound 4 the middle estimate is 1.8-fold (0.26 log units) above the measured one; the measured number falls inside the stated range.
By their numbers in this assay, from the lowest: compounds 1, 4, 3 and 2 (each within the scatter of the next, the first and the last beyond it).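

In this assay, for the compounds shown here, enlarging methyl to isopropyl on this aromatic carbon gives a 2.2-fold lower number from compound 2 to compound 4 (0.34 log units; beyond the scatter) and is the first change at this position to lie beyond the scatter, so the number here does respond to the group on this carbon, and the larger of these two carbon groups gives the lower number. Isopropyl and nitrile on the same carbon cannot be told apart, with a 1.2-fold lower number from compound 3 to compound 4 (0.08 log units; within the scatter) between them, and moving to the 4-isopropylphenyl group from the 2-cyanophenyl group also leaves the two compounds within the scatter, at a 1.3-fold higher number from compound 1 to compound 4 (0.10 log units; within the scatter) on this measure. No measurement available here gives a reason for the step from methyl to isopropyl.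

On these data alone, whether a tert-butyl group or a longer chain on this carbon would lower the number further or reverse the step remains open, as does the result of placing an amine or a carboxylic acid there. Isopropyl also appears at only this one place on the ring, so what it would do elsewhere on that ring is unknown.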